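Oxolane to methylpyrrolidine on the amide carbonyl

The compounds below may be only part of what the source reports. "The series", "measured", "known", "first", "only" and "open" are said of these compounds alone.

Of the compounds shown here, three of the shared core have been measured in an assay on HEK293 cells for negative allosteric modulation of metabotropic glutamate receptor 5 (Homo sapiens), read by FLIPR; on this read-out lower numbers stand for stronger inhibition and higher numbers for weaker inhibition. Compound 1 `O=C(c1ccc(Cl)cc1)N1CC(c2nc(-c3cccc(F)c3)no2)C1` reports only a limit, > 10000 nM. Compound 3 `O=C(C1CCC(C(F)(F)F)CC1)N1CC(c2nc(-c3cccc(F)c3)no2)C1` likewise reports only a limit, > 10000 nM. Compound 2 `O=C(C1CCCO1)N1CC(c2nc(-c3cccc(Cl)c3)no2)C1` gives 890 nM in this assay, and it is the only number shown: both other values sit at the limit of > 10000 nM in this assay, at which 2 of the 3 values shown sit, so compound 2 stands alone as the one measurable compound of the set. For the measured compounds named here, no step between measured compounds that differ in one place can be drawn from these three.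

Compound 4 `CC1CCN(C(=O)N2CC(c3nc(-c4cccc(Cl)c4)no3)C2)C1` is not yet measured. It differs from compound 2 in one place: 3-methylpyrrolidin-1-yl in place of oxolan-2-yl on a carbonyl carbon whose other neighbour is the amide-type nitrogen in a ring. The one hydrogen-bond acceptor of the leaving group is lost, and the entering group carries one more heavy atom. Going by the values given here, no measured step covers a change of this kind, so no direction is supported; the step is expected to stay within or only slightly beyond the scatter, estimated as a 1.7-fold higher number from compound 2 to compound 4 (0.23 log units; within the scatter). Compound 4 is accordingly expected at 1500 nM in this assay, within 300 nM to 8000 nM, with a real chance that only a limit is reported.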

Compound 4, half-maximal inhibitory concentration: > 10000 nM
Compound 4 ended at the assay's limit (the forecaster's own chance of this, stated with the estimate: 25%); middle value at least 6.6-fold (0.82 log units) away from the limit.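

In this assay, putting 3-methylpyrrolidin-1-yl in place of oxolan-2-yl on a carbonyl carbon whose other neighbour is the amide-type nitrogen in a ring gives an at least 11-fold higher number from compound 2 to compound 4 (1.05 log units; beyond the scatter). For the compounds shown here, this is the first readable evidence on this position: with the rest of the structure held constant, a change at this one place is enough to take a compound with a measurable value to a reported limit, so the position does not tolerate every five-membered ring with one hetero atom. The measurable part of the set now rests on compound 2 alone: the limit of > 10000 nM in this assay, at which 3 of the 4 values shown sit.

As far as these compounds go, this single pair does not separate the parts of the change, which swaps the ring oxygen for a ring nitrogen, moves the point of attachment from ring carbon to ring nitrogen and adds a methyl group, and the true size of the step remains open beyond what the limit allows. Unsubstituted pyrrolidin-1-yl, morpholin-4-yl and oxolan-3-yl on the same carbonyl would each address part of this, and the compounds shown give no reading for any of them.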